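Adding Bromo to the Fluorophenyl Ring of Compound 3

The source may report more compounds than this note shows. Statements on the series, on what has been measured and on what is new or still open speak of the compounds shown alone.

Compound 1 `CNC(=O)c1cc(Oc2ccc(NC(=O)c3cc4cccnc4n(-c4ccccc4F)c3=O)cc2)ccn1` gives 590 nM in a functional assay on NCI-H460 cells (Homo sapiens) for antiproliferative activity, read by MTT assay, with a stated time of 72 h; on this read-out higher numbers stand for weaker inhibition and lower numbers for stronger inhibition.
Compound 2 `CNC(=O)c1cc(Oc2ccc(NC(=O)c3cc4cccnc4n(-c4ccc(F)cc4)c3=O)cc2)ccn1` gives 210 nM.
Compound 3 `CCNC(=O)c1cc(Oc2ccc(NC(=O)c3cc4cccnc4n(-c4ccccc4F)c3=O)cc2)ccn1` gives 1230 nM.

Compound 3 stands highest of the three numbers, meaning the weakest inhibition. The two measured steps are a 2.1-fold higher number from compound 1 to compound 3 (0.32 log units; beyond the scatter) and a 2.8-fold lower number from compound 1 to compound 2 (0.45 log units; beyond the scatter). Compound 4 `CCNC(=O)c1cc(Oc2ccc(NC(=O)c3cc4cccnc4n(-c4ccc(Br)cc4F)c3=O)cc2)ccn1` differs from compound 3 by bromo in place of hydrogen on an aromatic carbon. Among the compounds with values here, only the second step touches the same ring, and it shows that changing what sits on that ring can move the number by a modest amount; no measured step tests a bromo group itself. A modest change is therefore expected, with direction uncertain, leaning toward a lower number: a 1.5-fold lower number from compound 3 to compound 4 (0.19 log units; within the scatter). Compound 4 is estimated at 800 nM, within a range from 250 nM to 2500 nM.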

Compound 4, half-maximal inhibitory concentration: 1790 nM
Compound 4: the middle estimate sits 2.2-fold (0.35 log units) below what was measured, and the stated range covers the measured number.
By their numbers in this assay, from the lowest: compound 2; then compound 1; then compounds 3 and 4 (each within the scatter of the next).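

In this assay, putting bromo in place of hydrogen on the 2-fluorophenyl ring, para to a large group, gives a 1.5-fold higher number from compound 3 to compound 4 (0.16 log units; within the scatter), so the two compounds cannot be told apart. Within the data shown here, this is the first look at a second group on this ring: the position can carry a bromine atom with no change beyond the scatter. No measured evidence here bears on why. Open questions are whether an amine or a methoxy group at this place would read the same, and whether bromo would read the same on compound 1.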